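A few compounds are considered here, and "the series" means these few. Any claim that something is new, unique, unknown or untested is made for them only; others in the source may bear on it.

Of the compounds shown here, three have so far been tested in an assay for inhibition of Rap guanine nucleotide exchange factor 3 (Homo sapiens), read by fluorescence, tested at 50 uM; a higher number here means a stronger effect of the compound at the concentration tested, a lower number a weaker effect. Compound 1, `CC1CCc2c(ccc(F)c2Br)N1C=O`, gives 42%. Compound 2, `CC1CCc2c(cc(Br)c(F)c2Br)N1`, gives 74.1%. Compound 3, `CC1CCc2c(Br)c(F)c(Br)c(Br)c2N1C=O`, gives 46%. Among these three numbers compound 2 stands highest: compound 3 lies nearest to it, with a number that is lower by a margin beyond the scatter, and compound 1 lies furthest from it, also beyond the scatter.

The next compound to be measured is compound 4, `CC(=O)N1c2cc(Br)c(F)c(Br)c2CCC1C`. It differs from compound 2 in one place: acetyl in place of hydrogen on a nitrogen on an aromatic ring in a ring.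

Among the compounds with values here, no pair of measured compounds differs in just one place, so no measured step exists that directly answers what this change does. What the numbers do show is that compound 2, which has a hydrogen on that nitrogen, gives a higher value than compound 1 and compound 3, in which that nitrogen carries no hydrogen, though those two also differ from compound 2 in other places. On that basis, a downward step of a number 22.1 percentage points lower from compound 2 to compound 4 (beyond the scatter) in this assay is expected for compound 4, larger than the scatter but not a collapse. Compound 4 is estimated to give 52% in this assay, within a range from 32% to 70%.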

Compound 4, a percentage reported as inhibition, at one concentration (the size of the read-out at that concentration, not a potency): 26.2%
Compound 4: middle estimate off by 25.8 percentage points, on the high side; measured number outside the range, below it.
By their numbers in this assay, from the lowest: compound 4; then compounds 1 and 3 (each within the scatter of the next); then compound 2.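

In this assay, within the data shown here, acetyl in place of hydrogen on the nitrogen gives a number 47.9 percentage points lower from compound 2 to compound 4 (beyond the scatter) and this is the first pair that differs in just one place. The rest of the structure is shared, so the fall in the read-out belongs to this single change. The earlier compounds shown here could only hint at this change. They also differ from compound 2 elsewhere. The position is therefore sensitive to what it carries, at least for this one replacement, but nothing available explains why the acetyl lowers the number.

A single pair compares only a hydrogen and an acetyl, so it cannot separate the loss of the hydrogen from the arrival of the acetyl itself. A methyl or ethyl on the same nitrogen, which would remove the hydrogen without adding a carbonyl, could help to tell these apart, while a longer acyl chain such as propanoyl would show whether the number changes further as the group grows.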